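Replacing the aryl piperazine cap with a carbamate

The compounds below may be only part of what the source reports. "The series", "measured", "known", "first", "only" and "open" are said of these compounds alone.

Compound 1 `N#Cc1ccc(COc2ccc(-c3cc(CN4CCN(Cc5ccc(C(F)(F)F)cc5)CC4)no3)cc2)cc1`: 4300 nM in a functional assay on Mahlavu cells (Homo sapiens) for antiproliferative activity, read by sulforhodamine B assay, with a stated time of 72 h; a lower number here means a stronger inhibitor, a higher number a weaker inhibitor
Compound 2 `N#Cc1cccc(COc2ccc(-c3cc(CN4CCN(c5ccc(C(F)(F)F)cc5)CC4)no3)cc2)c1`: 2700 nM in this assay

Compound 2 holds the lower of the two numbers, but compound 1 sits within the usual scatter of it, so the two cannot be ranked. Compound 3 `CC(C)(C)OC(=O)N1CCN(Cc2cc(-c3ccc(OCc4cccc(C#N)c4)cc3)on2)CC1` differs from compound 2 by tert-butoxycarbonyl in place of 4-(trifluoromethyl)phenyl on an amine nitrogen in a ring. Going by the values given here, no measured pair shows this change, so nothing about its size is known from the data. A shift toward a higher number is expected, beyond the scatter. Compound 3 is expected to give 7000 nM, with a range from 2500 nM to 20000 nM. The expected step is a 2.6-fold higher number from compound 2 to compound 3 (0.41 log units; beyond the scatter).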

Compound 3, half-maximal inhibitory concentration: 5600 nM
The estimate for compound 3 lay 1.3-fold (0.10 log units) above the measured number; the measured number falls inside the stated range.
By their numbers in this assay, from the lowest: compounds 2, 1 and 3 (each within the scatter of the next, the first and the last beyond it).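

In this assay tert-butoxycarbonyl in place of 4-(trifluoromethyl)phenyl on the amine nitrogen in the ring gives a 2.1-fold higher number from compound 2 to compound 3 (0.32 log units; beyond the scatter) and so only a modest step. This position therefore accepts a group with no ring and with a carbonyl in place of the aromatic ring of compound 2, at a modest cost in this read-out. No measurement here bears on why the number moves. On these data alone, whether a free ring amine, an acetyl group or a methanesulfonyl group on this nitrogen would give a lower or a higher number remains open.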